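The source may hold more compounds than are shown below. What is called first, only, known or untested is meant among the compounds shown, and "the series" means these compounds.

Working notes on the series. In a functional assay on CHO cells for positive allosteric modulation of metabotropic glutamate receptor 2 (Homo sapiens), read by GTPgammaS binding, with a stated time of 30 min (a higher number here means a larger maximal response, a lower number a smaller maximal response), compound 1 `CCCc1nnc2c(C#N)c(N3CCC(c4ccccc4)CC3)ccn12` gives 272%, the higher of the two numbers recorded; compound 2 `N#Cc1c(N2CCC(c3ccccc3)CC2)ccn2c(CC(F)(F)F)cnc12` gives 259%, which sits lower by a margin beyond the usual scatter. Within the data shown here, no pair among the measured compounds differs in one place only, so nothing is known directly about how a single change on the chain bound to the core shifts the maximal response.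

Compound 3 `N#Cc1c(N2CCC(c3ccccc3)CC2)ccn2c(CC3CC3)nnc12` is not yet measured in this assay. The change from compound 1 is cyclopropyl in place of ethyl on a saturated chain carbon bound to an aromatic carbon. Among the measured compounds shown here, with no comparable step on record, the expected step from compound 1 to compound 3, a number 7 percentage points lower from compound 1 to compound 3 (within the scatter), is small, a little downward, and within the scatter. For compound 3 the expected maximal response in this assay is 265%, likely between 235% and 295%.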

Compound 3, largest response reached (Emax), in percent of the reference or control that the assay uses: 278%
For compound 3 the middle estimate is 13 percentage points below the measured one; measured number inside the range.
By their numbers in this assay, from the lowest: compound 2; then compounds 1 and 3 (each within the scatter of the next).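

In this assay, the series now has its first step in one place only, a number 6 percentage points higher from compound 1 to compound 3 (within the scatter), for cyclopropyl in place of ethyl on a saturated chain carbon bound to an aromatic carbon. Read one bond further out, this is propyl to cyclopropylmethyl, and the maximal responses of the two compounds cannot be told apart, so a three-membered carbon ring can stand at this position on the shared core with the response still in the range of compound 1. No measurement on hand bears on the reason for this result.

This single step does not show how far the tolerance at this position extends. On these data alone, whether a longer chain such as pentyl, or a chain ending in an amine or a carboxylic acid, would shift the maximal response beyond the scatter remains open.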